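This account rests on a few compounds, and the source may have more. Where it says the series, first, only, none or still open, it means among the compounds named here.

Measured so far in an assay on isolated protein for inhibition of tyrosine-protein kinase receptor UFO (Homo sapiens), read by FRET and Z'-LYTE, with a stated time of 1.5 h; on this read-out higher numbers stand for weaker inhibition and lower numbers for stronger inhibition: compound 1 `CCc1ccc2c(c1)c(=O)c(C(=O)Nc1ccc(Oc3ncnc4[nH]cc(-c5ccccc5)c34)c(F)c1)c(C)n2C` gives 6 nM; compound 2 `CCc1ccc2c(c1)c(=O)c(C(=O)Nc1ccc(Oc3ncnc4[nH]ccc34)c(F)c1)c(C)n2C` gives 157 nM.

Among the compounds with values here, compound 2 stands highest of the two numbers, with compound 1 the only neighbour; the one step, a 26-fold higher number from compound 1 to compound 2 (1.42 log units; beyond the scatter), is large. Compound 3 `CCc1ccc2c(c1)c(=O)c(C(=O)Nc1ccc(Oc3ccnc(C(N)=O)c3Cl)c(F)c1)c(C)n2C` differs from compound 2 by a group of 10 heavy atoms (6 carbon, 2 nitrogen, 1 oxygen, 1 chlorine; one six-membered aromatic ring with 1 hetero atom) in place of a group of 9 heavy atoms (6 carbon, 3 nitrogen; one five-membered aromatic ring with 1 hetero atom, one six-membered aromatic ring with 2 hetero atoms), on an oxygen on an aromatic ring. Within the data shown here, no measured step covers this exchange of the whole group on the ether oxygen, so the step from compound 1 to compound 2 bears on it only as a sign that this region moves the read-out strongly. The direction is open; the estimate for compound 3 in this assay is 50 nM (range 8 nM to 400 nM), a step of a 3.1-fold lower number from compound 2 to compound 3 (0.50 log units; beyond the scatter) expected with wide uncertainty.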

Compound 3, half-maximal inhibitory concentration: > 10000 nM
Compound 3 ended at the assay's limit; the forecaster's own chance of this, stated with the estimate: 5%; middle value at least 200-fold (2.30 log units) from the limit.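

In this assay, replacing the group on the oxygen on an aromatic ring gives an at least 63-fold higher number from compound 2 to compound 3 (1.80 log units; beyond the scatter) and shows that the whole group there, not only the phenyl of compound 1, can move the read-out strongly. Compound 3 gives > 10000 nM as a limit of the assay, not a number, and the step is therefore only a lower bound: the limit of > 10000 nM in this assay, at which 1 of the 3 values shown sits.

Which part of the entering group carries the loss stays open, with the chlorine and the amide changing together. Also open, from the compounds shown here alone, is whether that ring regains inhibition with hydrogen in place of chlorine, or with an amine or a nitrile in place of the amide.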